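A Methoxypyridyl Variant in a Cycloheptyl Urea Series

The source may hold more compounds than are shown below. What is called first, only, known or untested is meant among the compounds shown, and "the series" means these compounds.

Compound 2 `CSc1cc(C)nc(C)c1NC(=O)N(Cc1ccc(Oc2ccc(F)cc2)cc1)C1CCCCCC1` is one of two ureas measured in an assay for inhibition of acyl-CoA:cholesterol acyltransferase (Oryctolagus cuniculus), using microsomes (a lower number here means a stronger inhibitor, a higher number a weaker inhibitor), where compound 2 gives 90 nM. Its companion, compound 1 `Cc1cc(Cl)c(NC(=O)N(Cc2ccc(Oc3ccc(F)cc3)cc2)C2CCCCCC2)c(Cl)n1`, gives 14 nM in this assay, so compound 2 stands at the higher, weaker end of the two numbers, with a 6.4-fold higher number from compound 1 to compound 2 (0.81 log units; beyond the scatter). Among the compounds with values here, that single step, which also exchanged one substituted pyridyl ring for another on the amide-type nitrogen, is the only measured comparison that bears on the new structure. Compound 3 `COc1nc(C)ccc1NC(=O)N(Cc1ccc(Oc2ccc(F)cc2)cc1)C1CCCCCC1` differs from compound 2 as follows: a group of 9 heavy atoms (7 carbon, 1 nitrogen, 1 oxygen; one six-membered aromatic ring with 1 hetero atom) in place of a group of 10 heavy atoms (8 carbon, 1 nitrogen, 1 sulfur; one six-membered aromatic ring with 1 hetero atom), on an amide-type nitrogen. The measured pair shows that a change confined to this ring moved the number by a modest amount, so a step of similar size, rather than none, is the reasonable expectation here; the direction is uncertain, but the entering group is the smaller of the two by the count given, and the weaker end is favoured. Compound 3 is therefore expected to give about 150 nM in this assay, with a plausible range from 40 nM to 600 nM. The expected step is estimated as a 1.7-fold higher number from compound 2 to compound 3 (0.22 log units; within the scatter).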

Compound 3, half-maximal inhibitory concentration: 39 nM
Estimate against measurement, compound 3: 3.8-fold (0.59 log units) above; the measured number lies below the stated range.
By their numbers in this assay, from the lowest: compound 1; then compound 3; then compound 2.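

In this assay, the 2-methoxy-6-methylpyridin-3-yl group on the amide-type nitrogen gives a 2.3-fold lower number from compound 2 to compound 3 (0.36 log units; beyond the scatter), so a second group with fewer heavy atoms than the group of compound 2 also carries a lower number, and compound 3 falls between the two earlier compounds. What the earlier pair could not show comes from the other new step, a 2.8-fold higher number from compound 1 to compound 3 (0.44 log units; beyond the scatter): the groups of compound 1 and compound 3 have the same count of heavy atoms, yet the number still moves beyond the scatter, so heavy-atom count alone does not settle the result at this position. No measurement shown here offers an explanation for either step.

Each of the three groups differs from the others in more than one feature, so these compounds cannot separate the contribution of the methoxy group from that of the other ring substituents. Going by these compounds, how an ethoxy or a dimethylamino group would compare with the methoxy group on the same ring also remains open.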